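The compounds below may be only part of what the source reports. "The series", "measured", "known", "first", "only" and "open" are said of these compounds alone.

Compound 1 `COc1cc(OC)c(OC)cc1/C=C/COC(=O)/C=C/c1ccccc1C(F)(F)F`, in a functional assay on the whole organism (strain Kunming) with Mus musculus as the target, with a stated time of 0.5 h, at a dose of 300 mg/kg by the intraperitoneal route (on this read-out lower numbers stand for a stronger effect and higher numbers for a weaker effect at the one dose given), compound 1 gives 75%. Compound 2 `COc1cc(OC)c(OC)cc1/C=C/COC(=O)/C=C/c1cccc(Br)c1`, in this assay compound 2 gives 50%.

For the measured compounds named here, compound 2 stands at the lowest of the two numbers; its only neighbour is compound 1, a number higher beyond the scatter. Compound 3 `COc1cc(OC)c(OC)cc1/C=C/COC(=O)/C=C/c1ccccc1Cl` differs from compound 2 by 2-chlorophenyl in place of 3-bromophenyl on a double-bonded chain carbon bound to a double-bonded chain carbon. Going by the values given here, the one measured step that touches this place, a number 25 percentage points lower from compound 1 to compound 2 (beyond the scatter), went down on leaving a 2-(trifluoromethyl)phenyl for a 3-bromophenyl. Returning to a 2-substituted phenyl, a 2-chlorophenyl, is therefore expected to move the number back up in this assay, by a number 15 percentage points higher from compound 2 to compound 3 (beyond the scatter). For compound 3 the estimate is 65%, expected between 45% and 85%.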

Compound 3, a percentage reported as activity, at one dose (the size of the read-out at that dose, not a potency): 50%
Estimate against measurement, compound 3: 15 percentage points above; low and high end bracket the measured number.
By their numbers in this assay, from the lowest: compounds 2 and 3 (each within the scatter of the next); then compound 1.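

In this assay, a 2-substituted phenyl does not by itself bring the higher number: 2-chlorophenyl in place of 3-bromophenyl gives no change at the digits printed from compound 2 to compound 3 (within the scatter). Chloro in place of trifluoromethyl on an aromatic carbon gives a number 25 percentage points lower from compound 1 to compound 3 (beyond the scatter), so among these three compounds the higher number goes with the 2-(trifluoromethyl)phenyl group alone. Nothing available explains this difference. The compounds shown leave open how an unsubstituted phenyl or a methoxyphenyl would read at this place, and whether changes to the shared core would alter this picture.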